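Sulfonyl substituent variation in a shared core series

This account rests on a few compounds, and the source may have more. Where it says the series, first, only, none or still open, it means among the compounds named here.

Measured so far:
compound 1 `O=C(/C=C/c1cn(S(=O)(=O)c2ccc(Cl)cc2)c2ccccc12)c1ccncc1` gives 35100 nM in a functional assay on HepG2 cells (Homo sapiens) for antiproliferative activity, read by MTT assay, with a stated time of 48 h; on this read-out higher numbers stand for weaker inhibition and lower numbers for stronger inhibition
compound 2 `CCCS(=O)(=O)n1cc(/C=C/C(=O)c2ccncc2)c2ccccc21` gives 46200 nM in this assay
compound 3 `O=C(/C=C/c1cn(S(=O)(=O)c2ccccc2[N+](=O)[O-])c2ccccc12)c1ccncc1` gives 31700 nM in this assay

Compound 3 holds the lowest of the three numbers, but the steps are a 1.1-fold lower number from compound 1 to compound 3 (0.04 log units; within the scatter) and a 1.5-fold lower number from compound 2 to compound 3 (0.16 log units; within the scatter), both within the scatter, so no order among the three can be claimed.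

Compound 4 `O=C(/C=C/c1cn(S(=O)(=O)c2cccc3ccccc23)c2ccccc12)c1ccncc1` differs from compound 3 by naphthalen-1-yl in place of 2-nitrophenyl on a sulfonyl sulfur. Every measured step changes the group on the sulfonyl sulfur: a 1.3-fold higher number from compound 1 to compound 2 (0.12 log units; within the scatter), a 1.1-fold lower number from compound 1 to compound 3 (0.04 log units; within the scatter), a 1.5-fold lower number from compound 2 to compound 3 (0.16 log units; within the scatter), all within the scatter. On that basis the step of a 1.0-fold higher number from compound 3 to compound 4 (0.02 log units; within the scatter) is expected to stay within the scatter, with no direction implied. For compound 4 the estimated value in this assay is 33000 nM, in the range 15000 nM to 75000 nM.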

Compound 4, half-maximal inhibitory concentration: 62900 nM
Compound 4: the middle estimate sits 1.9-fold (0.28 log units) below what was measured; low and high end bracket the measured number.
By their numbers in this assay, from the lowest: compounds 3, 1, 2 and 4 (each within the scatter of the next).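

In this assay the sulfonyl sulfur now also carries naphthalen-1-yl, with 2 six-membered aromatic rings, and the new steps are a 2.0-fold higher number from compound 3 to compound 4 (0.30 log units; within the scatter) and a 1.4-fold higher number from compound 2 to compound 4 (0.13 log units; within the scatter) and a 1.8-fold higher number from compound 1 to compound 4 (0.25 log units; within the scatter) and all three stay within the scatter. Among these compounds, the range of groups at this position is thus wider than in the earlier compounds, yet still no order can be claimed among the four compounds. No measurement at hand bears on why these numbers lie so close.

Going by these compounds, whether an amine or a carboxylic acid on the aryl group, or a longer chain in place of propyl, would carry the number beyond the scatter stays open. Also open, on these data alone, is whether changes to the shared core would do so.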